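Aryl Group Variation at the Carbonyl: Compound 1 to Compound 3

This account rests on a few compounds, and the source may have more. Where it says the series, first, only, none or still open, it means among the compounds named here.

Going by the values given here, compound 1 `O=C(/C=C/c1ccc2c(c1)B(O)OC2)c1cccs1` is one of two compounds so far measured in a functional assay on SK-OV-3 cells (Homo sapiens) for cytotoxicity, read by MTT assay, with a stated time of 48 h; on this read-out lower numbers stand for stronger inhibition and higher numbers for weaker inhibition. In this assay compound 1 gives 10400 nM, the highest number of the two. Compound 2 `O=C(/C=C/c1ccc2c(c1)B(O)OC2)c1ccc(C(F)(F)F)cc1` gives 3700 nM in this assay, a lower number, and the gap between compound 1 and compound 2 lies beyond the scatter.

Compound 3 `O=C(/C=C/c1ccc2c(c1)B(O)OC2)c1ccccc1F` has not yet been measured. Relative to compound 1 the change is 2-fluorophenyl in place of thiophen-2-yl on a carbonyl carbon. Among the compounds with values here, no step between measured compounds isolates this change, so the only guidance is that compound 1 and compound 2, which differ in the group on the carbonyl carbon, show numbers that differ beyond the scatter, the number of compound 1 being the higher. On that basis a step toward a lower number is expected for compound 3, of moderate size and not certain to clear the scatter, as expressed in a 1.7-fold lower number from compound 1 to compound 3 (0.24 log units; within the scatter). The estimate for compound 3 in this assay is 6000 nM, with an expected range from 2500 nM to 14000 nM.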

Compound 3, half-maximal inhibitory concentration: 3700 nM
The estimate for compound 3 lay 1.6-fold (0.21 log units) above the measured number; the range from low to high includes it.
By their numbers in this assay, from the lowest: compounds 2 and 3 (each within the scatter of the next); then compound 1.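

In this assay the group on the carbonyl carbon now has a step of its own: 2-fluorophenyl in place of thiophen-2-yl gives a 2.8-fold lower number from compound 1 to compound 3 (0.45 log units; beyond the scatter), a modest step. Compound 2 at 3700 nM and compound 3 at 3700 nM print the same number, so the two phenyl groups at this position, one carrying trifluoromethyl and the other fluorine, cannot be told apart in this read-out, while in these three compounds only thiophen-2-yl stands at a higher number. Nothing on hand bears on what lies behind this step.

Open, going by these compounds, is how a phenyl group with no substituent, or a group of another kind on the carbonyl carbon, such as an amine or a longer alkyl chain, would compare with 2-fluorophenyl and thiophen-2-yl. All the compounds shown also keep the core of compound 1 and its double-bonded chain unchanged, so what changes in those parts would do to the number remains open.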